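Working notes: two measured analogues and one proposed change

The source may report more compounds than this note shows. Statements on the series, on what has been measured and on what is new or still open speak of the compounds shown alone.

Measured so far in a functional assay on CHO cells for antagonist activity at prostaglandin E2 receptor EP3 subtype (Homo sapiens), read by cAMP accumulation, with a stated time of 30 min; a lower number here means a stronger inhibitor, a higher number a weaker inhibitor:
- compound 1 `CCC(/C=C1\OC(=O)NC1=O)(CC)c1ccc(-c2ccc3cccc(F)c3c2)[nH]c1=O`, for which compound 1 gives 61 nM
- compound 2 `CC(C)C(c1ccc(-c2ccc3cccc(F)c3c2)[nH]c1=O)C1NC(=O)NC1=O`, for which compound 2 gives 320 nM

Compound 2 holds the higher of the two numbers in this assay; compound 1 sits lower, a gap beyond the scatter, so compound 2 is the weaker of the pair as measured. No other comparisons are available.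

Compound 3 `CC(C)C(/C=C1\SC(=O)NC1=O)c1ccc(-c2ccc3cccc(F)c3c2)[nH]c1=O` is the next candidate. It differs from compound 2 by a group of 8 heavy atoms (4 carbon, 1 nitrogen, 2 oxygen, 1 sulfur; one five-membered non-aromatic ring with 2 hetero atoms) in place of a group of 7 heavy atoms (3 carbon, 2 nitrogen, 2 oxygen; one five-membered non-aromatic ring with 2 hetero atoms), on a saturated chain carbon bound to an aromatic carbon and a saturated chain carbon. Among the compounds with values here, this is the only change between the two.

Within the data shown here, with no matching step between measured compounds to lean on, the expectation rests on compound 1 with its 61 nM, whose ring is likewise joined through a double bond. The step from compound 2 to compound 3 is expected to be a 3.2-fold lower number from compound 2 to compound 3 (0.51 log units; beyond the scatter), a drop beyond the scatter. Compound 3 is therefore estimated at 100 nM, with a range from 30 nM to 350 nM.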

Compound 3, half-maximal inhibitory concentration: 27 nM
The estimate for compound 3 lay 3.7-fold (0.57 log units) above the measured number; the measured number lies below the stated range.
By their numbers in this assay, from the lowest: compound 3; then compound 1; then compound 2.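

In this assay, the saturated chain carbon bound to an aromatic carbon and a saturated chain carbon proves sensitive to the ring it carries: replacing the 2,5-dioxoimidazolidin-4-yl group with the sulfur-containing ring gives a 12-fold lower number from compound 2 to compound 3 (1.07 log units; beyond the scatter) as a large step. This single change alters several features together, including the ring atoms, the number of double bonds outside aromatic rings, and the counts of hydrogen-bond donors and acceptors. Nothing available explains the size of this step.

The compounds shown do not separate the contribution of the sulfur from that of the double bond, as no pair differs in only one of these features. As far as these compounds go, how a carboxylic acid or an amine in place of the ring would read in this assay also remains open.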